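The compounds below may be only part of what the source reports. "The series", "measured", "known", "first", "only" and "open" are said of these compounds alone.

Series notes, step from compound 3 to compound 4.

Three compounds have numbers in an assay (strain Wistar) for inhibition of Hormone-sensitive lipase (Rattus norvegicus), read by spectrophotometry; on this read-out lower numbers stand for stronger inhibition and higher numbers for weaker inhibition. Compound 1 `Cc1c(C(C)C)c(=O)on1C(=O)N(C)c1ccc(Cl)cc1` gives 17 nM. Compound 2 `CSc1nc(-c2ccc(Cl)cc2)nn1C(=O)N1CCCCC1` gives 1.76 nM. Compound 3 `O=C(N1CCCCC1)n1nc(-c2ccc(Cl)cc2)nc1SCC1CC1` gives 3.53 nM. On these numbers compound 3 stands second highest; its nearest neighbour is compound 2, and the gap a 2.0-fold higher number from compound 2 to compound 3 (0.30 log units; within the scatter) lies within the scatter, so no order between the two can be read. Against compound 1 the number of compound 3 is clearly lower, the two values standing well apart.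

Compound 4 `O=C(N1CCCCC1)n1nc(-c2ccc(Cl)cc2)nc1SC1CCCCC1` is not yet measured. It differs from compound 3 by cyclohexyl in place of cyclopropylmethyl on a sulfur and keeps everything else of the shared core, the piperidine amide and the chlorophenyl group.

Within the data shown here, the only measured step that touches this position on the sulfur is the one from compound 2 to compound 3, where a 2.0-fold higher number from compound 2 to compound 3 (0.30 log units; within the scatter) was recorded; that change stayed within the scatter. Among the measured compounds shown here, no step among the measured compounds trades one saturated carbon ring for another on this sulfur, so the present change is read only by analogy. Given the small size of a 2.0-fold higher number from compound 2 to compound 3 (0.30 log units; within the scatter), a step of a 1.3-fold higher number from compound 3 to compound 4 (0.11 log units; within the scatter) within the scatter is expected, with no clear direction. Compound 4 is therefore estimated at 4.5 nM, in a range from 1.5 nM to 14 nM.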

Compound 4, half-maximal inhibitory concentration: 882 nM
Estimate against measurement, compound 4: 200-fold (2.29 log units) below; measured number outside the range, above it.
By their numbers in this assay, from the lowest: compounds 2 and 3 (each within the scatter of the next); then compound 1; then compound 4.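

In this assay, the group on this sulfur clearly matters: the step to cyclohexyl is large (a 250-fold higher number from compound 3 to compound 4 (2.40 log units; beyond the scatter)), and it is also large when measured from the methyl compound (a 500-fold higher number from compound 2 to compound 4 (2.70 log units; beyond the scatter)), whereas the earlier step from methyl to cyclopropylmethyl stayed within the scatter (a 2.0-fold higher number from compound 2 to compound 3 (0.30 log units; within the scatter)). Tolerance of the first two groups therefore does not extend to every saturated carbon group at this place, and among compound 2, compound 3 and compound 4 only cyclohexyl stands apart from the others. The change from compound 3 to compound 4 enlarges the ring from three members to six and also replaces a chain carbon bound to the sulfur with a ring carbon, and no evidence shown here explains the large rise or separates these two parts.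

The compounds shown leave open whether the loss follows ring size or the absence of that chain carbon, a question that cyclohexylmethyl and cyclobutyl on the same sulfur would address. They also leave open how far an open chain such as n-butyl or a branched isopropyl group would stay with the low numbers of compound 2 and compound 3.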